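A few compounds are considered here, and "the series" means these few. Any claim that something is new, unique, unknown or untested is made for them only; others in the source may bear on it.

Measured compounds:
compound 1, `CC(C)C(c1nnc[nH]1)c1ccc(-c2ccc3cccc(F)c3c2)[nH]c1=O`, 0.552 h
compound 2, `CC(C)C(/C=C1\CCNC1=O)c1ccc(-c2ccc3cccc(F)c3c2)[nH]c1=O`, 0.345 h
compound 3, `CC(C)C(CC(N)=O)c1ccc(-c2ccc3cccc(F)c3c2)[nH]c1=O`, a limit of the assay, < 0.0667 h

In an ADME assay on microsomes from liver (Rattus norvegicus) for metabolic stability (a lower number here means that the compound disappears faster, a higher number that the compound lasts longer), compound 1 gives 0.552 h, the highest of the two numbers. Compound 2 sits close, with a 1.6-fold lower number from compound 1 to compound 2 (0.20 log units; within the scatter). Compound 3 reports only a limit, (the limit of < 0.0667 h in this assay, at which 1 of the 3 values shown sits), so an at least 8.2-fold lower number from compound 1 to compound 3 (0.91 log units; beyond the scatter). Compound 4, `Cc1nc(C(c2ccc(-c3ccc4cccc(F)c4c3)[nH]c2=O)C(C)C)[nH]c1C`, is not yet measured; it differs from compound 1 by 4,5-dimethyl-1H-imidazol-2-yl in place of 4H-1,2,4-triazol-3-yl on a saturated chain carbon bound to an aromatic carbon and a saturated chain carbon. For the measured compounds named here, of the measured steps, the one from compound 1 to compound 2 bears most closely on this, since it also swaps the ring at that position for another ring and stayed within the scatter; the open-chain change to compound 3 is the one that fell beyond it. Compound 4 is therefore expected to stay within the scatter of compound 1, with a 1.2-fold lower number from compound 1 to compound 4 (0.09 log units; within the scatter). The estimate for compound 4 is 0.45 h, ranging from 0.18 h to 1.1 h.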

Compound 4, half-life: 0.0733 h
Beside the measured number, compound 4's estimate is 6.1-fold (0.79 log units) above it; the whole stated range lies above it.
By their numbers in this assay, from the lowest: compound 4; then compounds 2 and 1 (each within the scatter of the next). At a limit, below all of these: compound 3.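

Keeping a five-membered aromatic ring at this position does not by itself hold the number in this assay: 4,5-dimethyl-1H-imidazol-2-yl in place of 4H-1,2,4-triazol-3-yl gives a modest step: a 7.5-fold lower number from compound 1 to compound 4 (0.88 log units; beyond the scatter). Against the non-aromatic ring there is also a 4.7-fold lower number from compound 2 to compound 4 (0.67 log units; beyond the scatter), so having a ring here does not guarantee the higher numbers. Compound 3 stands at a limit of the assay: the limit of < 0.0667 h in this assay, at which 1 of the 4 values shown sits. Read from that limit, the step gives only a floor: an at least 1.0-fold higher number from compound 3 to compound 4 (0.04 log units; that floor lies within the scatter).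

Still open, from the compounds shown here alone, is whether the methyl groups or the change of ring nitrogens accounts for the drop. An imidazolyl ring without methyl groups, or a triazolyl ring bearing methyl groups, would separate the two.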